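Adding Ethyl to the Ring of Compound 1

The source may hold more compounds than are shown below. What is called first, only, known or untested is meant among the compounds shown, and "the series" means these compounds.

Measured in a functional assay on HA22T cells for cytotoxicity against HA22T cell line (Homo sapiens); a lower number here means a stronger inhibitor, a higher number a weaker inhibitor
- compound 1 (`N#C/N=C1\N(CCCCCCOc2ccc(Cl)cc2)C(=O)CN1c1ccncc1`) gives (3860 nM)
- compound 2 (`N#C/N=C1\N(CCCCCCCOc2ccc(Cl)cc2)C(=O)CN1c1ccncc1`) gives (3500 nM)

Only these two compounds have been measured, and they stand level within the scatter, so compound 1 sits with compound 2 and no order can be drawn between them. The next compound, compound 3 (`CCC1C(=O)N(CCCCCCOc2ccc(Cl)cc2)/C(=N\C#N)N1c1ccncc1`), has not yet been measured. It keeps the chain of compound 1 and carries ethyl in place of hydrogen on a saturated ring carbon.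

Going by the values given here, the one measured step is (a 1.1-fold lower number from compound 1 to compound 2 (0.04 log units; within the scatter)). It lies within the scatter, but it alters the chain and not the ring. Among the compounds with values here, no measured compound carries any group on that ring carbon, so the data give no direct guide to this change, and neither its size nor its direction can be read from them. With nothing to point either way, no shift beyond the scatter is expected, though the uncertainty is wide. The expected step in this assay is small (a 1.0-fold lower number from compound 1 to compound 3 (0.01 log units; within the scatter)). The estimated value for compound 3 is 3800 nM (estimated range 1200 nM to 11000 nM).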

Compound 3, half-maximal inhibitory concentration: 5130 nM
The estimate for compound 3 lay 1.4-fold (0.13 log units) below the measured number; the range from low to high includes it.
By their numbers in this assay, from the lowest: compounds 2, 1 and 3 (each within the scatter of the next).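

Compound 3 is the only compound shown with any group on the saturated ring carbon next to the ring atom that bears a pyridin-4-yl group, and in this assay the step is a 1.3-fold higher number from compound 1 to compound 3 (0.12 log units; within the scatter). This puts compound 1 and compound 3 level within the scatter, so this position accepts ethyl in place of hydrogen, a gain of 2 heavy atoms, with no shift in this assay that can be told from the scatter of repeated measurements. No independent measurement is available to bear on this outcome or to say what lies behind it.

The compounds shown cover only ethyl on this ring carbon, so they leave open how a smaller methyl, a bulkier phenyl or a charged carboxylic acid would fare there, and whether any group at this position can move the number beyond the scatter in either direction. They also leave open whether ethyl on this ring carbon would give a similar result when paired with the longer chain of compound 2, or with a shorter chain than either of those compounds carries.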